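Ring size of the amine on the shared core

This account rests on a few compounds, and the source may have more. Where it says the series, first, only, none or still open, it means among the compounds named here.

The series is read in a functional assay on ileum for antagonist activity at Substance-P receptor (Cavia porcellus); on this read-out lower numbers stand for stronger inhibition and higher numbers for weaker inhibition. Compound 1 `FC(F)(F)c1cc(COc2cccnc2-c2ccccc2)cc(C(F)(F)F)c1` gives 25.7 nM in this assay. Compound 2 `O=C1c2c(-c3ccccc3)cc(N3CCCC3)nc2OCCCN1Cc1cc(C(F)(F)F)cc(C(F)(F)F)c1` gives 13.8 nM in this assay; it stands at the low end of the two numbers, but its gap to compound 1 lies within the scatter, so the two are not distinguished by these data.

Compound 3 `O=C1c2c(-c3ccccc3)cc(N3CCCCC3)nc2OCCCN1Cc1cc(C(F)(F)F)cc(C(F)(F)F)c1` has not yet been measured. Its change from compound 2 is piperidin-1-yl in place of pyrrolidin-1-yl on an aromatic carbon; the rest of the structure is unchanged. Going by the values given here, no step between two measured compounds covers a change of this kind, so the data give no direction. The one-carbon enlargement of a saturated ring with the same acceptor count is expected to leave this assay close to where compound 2 stands, the most likely outcome being a step that stays within the scatter.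

Compound 3 is therefore expected to give about 15 nM in this assay, within a range from 5 nM to 45 nM. The step implied by this estimate is a 1.1-fold higher number from compound 2 to compound 3 (0.04 log units; within the scatter), that is, expected to be none beyond the scatter.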

Compound 3, antagonist equilibrium constant: 13.2 nM
Compound 3: the middle estimate sits 1.1-fold (0.06 log units) above what was measured; the range from low to high includes it.
By their numbers in this assay, from the lowest: compounds 3, 2 and 1 (each within the scatter of the next).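

Going by these compounds alone, this is the first step read at this position, the aromatic carbon next to the ring nitrogen: in this assay, piperidin-1-yl in place of pyrrolidin-1-yl gives a 1.0-fold lower number from compound 2 to compound 3 (0.02 log units; within the scatter). On the shared core, this read-out therefore does not distinguish the five-membered ring from the six-membered ring, and the added ring carbon produces no step beyond the scatter; this holds for this one pair and sets no trend in ring size. Nothing available bears on why the two amines read alike.

As far as these compounds go, how this assay responds to a ring with a second hetero atom, such as morpholin-4-yl or piperazin-1-yl, or to an open-chain amine such as dimethylamino, remains open, so the pair does not show whether the position accepts amines in general or only saturated rings with a single nitrogen. Also open, from the compounds shown here alone, is whether a larger ring, azepan-1-yl, would still stay within the scatter of these two compounds, and whether the same match would hold with another group in place of the phenyl group.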